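The compounds below may be only part of what the source reports. "The series", "measured", "known", "first", "only" and "open" are said of these compounds alone.

Series notes. Variation in this set sits on the amine nitrogen in a ring of the shared core of compound 2 `COc1ccc2[nH]c3c(c2c1)CCNC31CCN(Cc2ccc(F)c(Cl)c2F)CC1`. In an assay on FRT cells for positive allosteric modulation of Cystic fibrosis transmembrane conductance regulator variant N1303K (Homo sapiens), in the presence of a further agent that is not named here (a higher number here means that more compound is needed for the effect, a lower number that less compound is needed), compound 1 `COc1ccc2[nH]c3c(c2c1)CCNC31CCN(Cc2cc(Cl)ccc2[N+](=O)[O-])CC1` gives 7100 nM, compound 2 gives 4500 nM and compound 3 `COc1ccc2[nH]c3c(c2c1)CCNC31CCN(Cc2c(F)c(F)c(F)c(F)c2F)CC1` gives 2100 nM. Compound 2 stands second highest of the three numbers: its gap to compound 1 lies within the scatter, while compound 3 shows a lower number beyond the scatter. Compound 4 `COc1ccc2[nH]c3c(c2c1)CCNC31CCN(C(C)c2ccccc2)CC1` differs from compound 2 by 1-phenylethyl in place of 3-chloro-2,4-difluorobenzyl on an amine nitrogen in a ring. Going by the values given here, only one measured step bears on such an aryl swap: a 1.6-fold lower number from compound 1 to compound 2 (0.20 log units; within the scatter), which stayed within the scatter. Nothing measured here covers replacing a benzyl by a 1-phenylethyl or removing all halogens, so no step beyond the scatter is expected, the estimated change being a 1.3-fold higher number from compound 2 to compound 4 (0.12 log units; within the scatter). Compound 4 is expected to give 6000 nM in this assay, within 2500 nM to 15000 nM.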

Compound 4, half-maximal effective concentration: 20000 nM
Compound 4: middle estimate off by 3.3-fold (0.52 log units), on the low side; measured number above the stated range.
By their numbers in this assay, from the lowest: compound 3; then compounds 2 and 1 (each within the scatter of the next); then compound 4.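

At the amine nitrogen in a ring, 1-phenylethyl in place of 3-chloro-2,4-difluorobenzyl gives a 4.4-fold higher number from compound 2 to compound 4 (0.65 log units; beyond the scatter) in this assay, whereas the earlier aryl swap stayed within the scatter at a 1.6-fold lower number from compound 1 to compound 2 (0.20 log units; within the scatter) in the same read-out. This position therefore does not tolerate every change, and this one both adds a branch to the chain and removes all halogens. Nothing available here accounts for the rise.

Which of those two differences carries the step stays open. An unsubstituted benzyl on the same nitrogen would separate them.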